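The source may hold more compounds than are shown below. What is called first, only, known or untested is meant among the compounds shown, and "the series" means these compounds.

Compound 1, with the structure `ClCc1ccc(Cn2cnc3c(Cl)ncnc32)cc1`, is the most toxic of the three measured compounds in a functional assay on ACHN cells (Homo sapiens) for cytotoxicity, read by sulforhodamine B assay, with a stated time of 48 h (on this read-out lower numbers stand for higher toxicity in this test and higher numbers for lower toxicity in this test), where compound 1 gives 3800 nM. Compound 2, `Nc1nc(Cl)c2ncn(Cc3ccc(CCl)cc3)c2n1`, gives 64600 nM in this assay. The two differ by a single change, (amino in place of hydrogen on an aromatic carbon), and that change produced a 17-fold higher number from compound 1 to compound 2 (1.23 log units; beyond the scatter).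

Compound 3, `ClCc1ccccc1Cn1cnc2c(Cl)ncnc21`, shares its atoms with compound 1 but joins them differently; the difference between the two cores is not broken down here. In this assay compound 3 gives 26900 nM, a number that stands between the other two and beyond the scatter from each.

Compound 4, `Nc1nc(Cl)c2ncn(Cc3ccccc3CCl)c2n1`, has not yet been measured. Among the compounds with values here, it arises from compound 3 by amino in place of hydrogen on an aromatic carbon, the same change at the same kind of place as the one already seen between compound 1 and compound 2. On that basis the change is expected to bring an 11-fold higher number from compound 3 to compound 4 (1.05 log units; beyond the scatter), resting on the step of a 17-fold higher number from compound 1 to compound 2 (1.23 log units; beyond the scatter) observed before. Compound 4 is therefore estimated to give 300000 nM in this assay, with a likely range from 80000 nM to 1000000 nM.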

Compound 4, concentration lethal to 50% of the cells: 75900 nM
Compound 4: middle estimate off by 4.0-fold (0.60 log units), on the high side; measured number below the stated range.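

In this assay, amino in place of hydrogen on an aromatic carbon gave a 2.8-fold higher number from compound 3 to compound 4 (0.45 log units; beyond the scatter), so the number rose on this core as it had on the core of compound 1. The direction of the change carried over from one core to the other, but its size did not: the same change on two cores in this assay, a 17-fold higher number (1.23 log units; beyond the scatter) from compound 1 to compound 2 and a 2.8-fold higher number (0.45 log units; beyond the scatter) from compound 3 to compound 4, 6.0-fold (0.78 log units) apart, beyond the scatter of two such steps This shows that, in these two pairs, a step read on one core could not be moved to the other at full size; it does not show what sets the size of the step, and two pairs cannot tell whether the direction would hold on a further core.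

The compounds shown leave open how a methylamino group, a hydroxyl group or a methoxy group would act in place of the amino on that same aromatic carbon. They also leave open whether the gap between the two steps would appear on any read-out other than this assay.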